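The compounds below may be only part of what the source reports. "The series", "measured", "known", "first", "only" and "open" are said of these compounds alone.

Compound 1, `O=C1CCCC/C1=C\c1ccc(OC(=O)c2ccc(Cl)cc2)cc1`, is the weaker of two measured compounds in the sense of standing lowest: in a functional assay on L1210 cells (Mus musculus) (a lower number here means a stronger inhibitor, a higher number a weaker inhibitor), compound 1 gives 3330 nM. Compound 2, `CN(C)CC1CCC/C(=C\c2ccc(OC(=O)c3ccc(Cl)cc3)cc2)C1=O`, gives 5610 nM in this assay, and the step of a 1.7-fold higher number from compound 1 to compound 2 (0.23 log units; within the scatter), made by putting (dimethylamino)methyl in place of hydrogen on a saturated ring carbon, is within the scatter. The next compound, compound 3, `O=C(CCc1ccccc1)Oc1ccc(/C=C2\CCCCC2=O)cc1`, changes a different part of the molecule: phenethyl in place of 4-chlorophenyl on a carbonyl carbon. Going by the values given here, no measured step touches this carbonyl carbon, so the only guide is that the one change seen so far left the number essentially where it was. Compound 3 is therefore expected to show no step beyond the scatter, and the estimated step of a 1.1-fold higher number from compound 1 to compound 3 (0.02 log units; within the scatter) carries a broad margin. The estimate for compound 3 in this assay is 3500 nM, with a range from 1200 nM to 10000 nM.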

Compound 3, half-maximal inhibitory concentration: 52400 nM
Compound 3: middle estimate off by 15-fold (1.18 log units), on the low side, and the stated range ends below it.
By their numbers in this assay, from the lowest: compounds 1 and 2 (each within the scatter of the next); then compound 3.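

In this assay, phenethyl in place of 4-chlorophenyl on the carbonyl carbon gives a 16-fold higher number from compound 1 to compound 3 (1.20 log units; beyond the scatter), so this place, unlike the saturated ring carbon changed in compound 2, moves the number well beyond the scatter. The two groups each hold one six-membered aromatic ring of carbon only and neither has a hydrogen-bond donor or acceptor, so these counts do not separate them; the leaving group holds chlorine and the entering group does not. Nothing available explains why the number rises this far.

The compounds shown leave open whether the loss of the chlorine or the arrival of the chain in phenethyl accounts for the step, as the one change does both. A plain phenyl or a benzyl on this carbonyl carbon would pull the two apart.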